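Adding a phenyl to the ring amine's methyl: compound 3

This account rests on a few compounds, and the source may have more. Where it says the series, first, only, none or still open, it means among the compounds named here.

Among the measured compounds shown here, compound 2 `CO[C@@]12CCN(C)C[C@H]1[C@H](c1ccc(F)cc1)C(C#N)=C(N)O2` gives 19400 nM in a functional assay on trachea (Cavia porcellus) (a lower number here means a stronger inhibitor, a higher number a weaker inhibitor), and holds the lower of the two numbers known here. Compound 1 `CO[C@@]12CCN(Cc3ccccc3)C[C@H]1[C@H](c1ccccc1)C(C#N)=C(N)O2` gives 22600 nM in this assay, and the two values lie within the scatter of each other, so neither compound can be called the stronger one. Compound 3 `CO[C@@]12CCN(Cc3ccccc3)C[C@H]1[C@H](c1ccc(F)cc1)C(C#N)=C(N)O2` is not yet measured. It carries phenyl in place of hydrogen on a saturated chain carbon bound to an amine nitrogen in a ring. For the measured compounds named here, no measured pair shows this change on its own, so no step beyond the scatter is expected in either direction. For compound 3 the expected value is 20000 nM, within 8000 nM to 50000 nM. The expected step is a 1.0-fold higher number from compound 2 to compound 3 (0.01 log units; within the scatter), amounting to no real change.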

Compound 3, half-maximal inhibitory concentration: 17200 nM
Compound 3: middle estimate off by 1.2-fold (0.07 log units), on the high side; measured number inside the range.
By their numbers in this assay, from the lowest: compounds 3, 2 and 1 (each within the scatter of the next).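

In this assay, going from methyl to benzyl on the amine nitrogen in a ring gives a 1.1-fold lower number from compound 2 to compound 3 (0.05 log units; within the scatter), so this place accepts the added phenyl without a difference that can be told from the scatter. Fluoro in place of hydrogen on an aromatic carbon, now seen on its own, gives a 1.3-fold lower number from compound 1 to compound 3 (0.12 log units; within the scatter), which is also within the scatter. Nothing available here explains either result.

On these data alone, whether a longer chain or a carboxylic acid in place of the phenyl would move the number beyond the scatter remains open, as does the effect of chloro in place of fluoro.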